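Aryl exchange at the saturated ring carbon of the core

The compounds below may be only part of what the source reports. "The series", "measured", "known", "first", "only" and "open" are said of these compounds alone.

Measured so far:
compound 1, `N#CC1=C(N)N(c2ccc(S(N)(=O)=O)cc2)C2=C(C(=O)CCC2)C1c1ccc(O)cc1` — 100%
compound 2, `N#CC1=C(N)N(c2ccc(S(N)(=O)=O)cc2)C2=C(C(=O)CCC2)C1/C=C/c1ccccc1` — 40%

In a functional assay on Ehrlich cells (Mus musculus) for antiproliferative activity, read by trypan blue exclusion, with a stated time of 2 h, tested at 50 ug/mL (on this read-out lower numbers stand for a weaker effect and higher numbers for a stronger effect at the one concentration tested), compound 1 gives 100% and compound 2 gives 40%. Compound 2 thus stands lowest of the two numbers; its nearest neighbour is compound 1, whose number is higher, beyond the scatter. Within the data shown here, the one step measured, a number 60 percentage points lower from compound 1 to compound 2 (beyond the scatter), came with 2-phenylethenyl in place of 4-hydroxyphenyl on a saturated ring carbon.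

Compound 3, `COc1ccccc1C1C(C#N)=C(N)N(c2ccc(S(N)(=O)=O)cc2)C2=C1C(=O)CCC2`, is not yet measured. Its change from compound 2 is 2-methoxyphenyl in place of 2-phenylethenyl on a saturated ring carbon

Among the measured compounds shown here, only the step from compound 1 to compound 2 bears on this change, and it concerns a different pair of groups; it shows that exchanging the group at this saturated ring carbon can shift this assay by a large amount. Since compound 3 returns to a six-membered aromatic ring at this position, as in compound 1, the read-out is expected to rise. The estimate amounts to an expected step of a number 30 percentage points higher from compound 2 to compound 3 (beyond the scatter). For compound 3 the expected value in this assay is 70%, with a range from 40% to 100%.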

Compound 3, a percentage reported as activity, at one concentration (the size of the read-out at that concentration, not a potency): 0%
Compound 3: the middle estimate sits 70 percentage points above what was measured, and the stated range ends above it.
By their numbers in this assay, from the lowest: compound 3; then compound 2; then compound 1.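

In this assay, an aromatic ring at this saturated ring carbon does not by itself carry the effect: 2-methoxyphenyl in place of 4-hydroxyphenyl gives a number 100 percentage points lower from compound 1 to compound 3 (beyond the scatter). The 2-phenylethenyl group has the same count of heavy atoms as 2-methoxyphenyl and also holds one six-membered aromatic ring, yet the exchange gives a number 40 percentage points lower from compound 2 to compound 3 (beyond the scatter), so among these two groups neither of those counts tracks the read-out. Nothing at hand accounts for these differences.

Compound 1 and compound 3 differ in both the group on the phenyl ring and where it sits, so these compounds leave open whether the drop belongs to the methoxy group, to its place on the ring, or to the loss of the hydroxyl group. Also open, from the compounds shown here alone, is how this position responds to a phenyl ring carrying an amine or a carboxylic acid, or to a longer saturated carbon chain, and each reading here is the size of the effect at one concentration rather than a potency.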